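The source may report more compounds than this note shows. Statements on the series, on what has been measured and on what is new or still open speak of the compounds shown alone.

In a functional assay for inhibition, with Homo sapiens as the target (on this read-out higher numbers stand for weaker inhibition and lower numbers for stronger inhibition), compound 1 (`O=C(O)CCCCCCCCn1nc(-c2ccccc2)c(-c2ccccc2)c1-c1ccccc1`) gives 400 nM. Compound 2 (`O=C(O)CCCCCCCCn1nc(-c2ccccc2)cc1-c1ccccc1`) reads > 66000 nM, which is a limit and not a number. Compound 3 (`O=C(O)CCCCCCCCn1nc(-c2ccccc2)c(Cc2ccccc2)c1-c1ccccc1`) reads > 68000 nM, which is likewise only a limit. Compound 3 therefore has no exact place on the scale, and a step that the two limits leave unreadable from compound 2 to compound 3 cannot be read.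

Compound 4 (`CCc1c(-c2ccccc2)nn(CCCCCCCCC(=O)O)c1-c1ccccc1`) is reached from compound 3 by one change, methyl in place of phenyl on a saturated chain carbon bound to an aromatic carbon, which can also be read as benzyl to ethyl.

Going by the values given here, two measured steps bear on this change. Hydrogen in place of phenyl on an aromatic carbon gave an at least 160-fold higher number from compound 1 to compound 2 (2.21 log units; beyond the scatter), and benzyl in place of phenyl on an aromatic carbon gave an at least 170-fold higher number from compound 1 to compound 3 (2.23 log units; beyond the scatter). Both are large and beyond the scatter, and both end at a limit. Compound 4 also lacks the phenyl of compound 1 on that aromatic carbon, so it is expected to stay with compound 2 and compound 3 on the weak side of this assay, with no large move toward compound 1.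

The estimated step is an at least 1.5-fold lower number from compound 3 to compound 4 (0.17 log units; that floor lies within the scatter), and it may well not be readable if only a limit is reported. For compound 4 the expected value is 45000 nM, with an estimated range from 8000 nM to 70000 nM.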

Compound 4, half-maximal inhibitory concentration: > 79000 nM
Compound 4: only a limit was reported (the forecaster's own chance of this, stated with the estimate: 65%); middle value at least 1.7-fold (0.24 log units) from the limit.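

In this assay, replacing the phenyl on the aromatic carbon with ethyl gives an at least 190-fold higher number from compound 1 to compound 4 (2.29 log units; beyond the scatter), which makes ethyl the third group, after hydrogen and benzyl, whose exchange for that phenyl comes with a large step that ends at a limit. Compound 4 reads > 79000 nM in this assay, and this is a limit. The steps from compound 3 to compound 4 and from compound 2 to compound 4 cannot be read, so hydrogen, benzyl and ethyl cannot be ranked against one another, and among the four compounds shown only compound 1, with phenyl on that carbon, has an exact value.

On these data alone, how far compound 2, compound 3 and compound 4 each lie beyond their limits stays open. As far as these compounds go, it also stays open whether the exact value depends on phenyl itself or whether another ring on that aromatic carbon, such as cyclohexyl or pyridyl, would also give a measurable value.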